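The source may hold more compounds than are shown below. What is called first, only, known or untested is meant among the compounds shown, and "the series" means these compounds.

Three compounds were measured in a functional assay on HL-60 cells (Homo sapiens) for antiproliferative activity, read by MTT assay (on this read-out lower numbers stand for stronger inhibition and higher numbers for weaker inhibition), with these results

Compound 1 `O[C@@H]1[C@@H](OCc2ccccc2)[C@H](OCc2ccccc2)[C@@H](COCc2ccccc2)O[C@@H]1Cc1ccccc1` gives "not active" (no number reported)
Compound 2 `CC(=O)O[C@@H]1[C@@H](OCc2ccccc2)[C@H](OCc2ccccc2)[C@@H](COCc2ccccc2)O[C@H]1Cc1ccccc1` gives "not active" (no number reported)
Compound 3 `O[C@@H]1[C@@H](OCc2ccccc2)[C@H](OCc2ccccc2)[C@@H](COCc2ccccc2)O[C@H]1Cc1ccccc1` gives 8700 nM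

Of the three, only compound 3 yields a number (8700 nM), so it stands alone, with compound 1 and compound 2 both reported without one. The contrast between compound 3 and compound 1 ("not active" (no number reported)) is striking, given what separates them (the fact that compounds 1 and 3 differ only in the configuration as drawn).

Compound 4 (`OC[C@H]1O[C@@H](Cc2ccccc2)[C@H](O)[C@@H](OCc2ccccc2)[C@@H]1OCc1ccccc1`), not yet measured, departs from compound 3 by a single change, (benzyloxy)methyl to hydroxymethyl (hydrogen in place of benzyl on an oxygen on a saturated carbon). That is hydrogen in place of benzyl on an oxygen on a saturated carbon. Going by the values given here, no measured pair in this set shows that change, so any expectation for it is loose. The activity of compound 3 (8700 nM) is already modest, and it disappears in compound 1 ("not active" (no number reported)) with only the configuration altered, so a further loss seems more likely than a gain. A moderate move toward weaker inhibition in this assay is expected, and compound 4 may well give no number at all. The expected step is (a 2.3-fold higher number from compound 3 to compound 4 (0.36 log units; beyond the scatter)). Compound 4 is estimated at 20000 nM (expected range 7000 nM to 60000 nM).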

Compound 4, half-maximal inhibitory concentration: 20200 nM
Compound 4: the middle estimate sits 1.0-fold (0.00 log units) below what was measured; low and high end bracket the measured number.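

In this assay, going by these compounds alone, putting hydrogen in place of benzyl on the oxygen on a saturated carbon gives a 2.3-fold higher number from compound 3 to compound 4 (0.37 log units; beyond the scatter), the first step in this set that can be read as a number, and it runs toward weaker inhibition. The benzyl group at this position is therefore not required for a measurable value on these cells, although its removal costs a modest part of an activity that was already weak, and the change differs in kind from the change in configuration that separates compound 1 from compound 3, where no number remains. What lies behind the size of this step cannot be said from anything measured in this set.

The compounds shown leave open whether a small group on this oxygen, such as a methyl ether, or an amine in place of the hydroxymethyl group, would stay close to compound 3 or move further from it. They also leave open whether hydrogen in place of benzyl at the other benzyloxy groups would give a step of similar size, and whether this step would hold in the configuration of compound 1.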